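Aryl sulfonamide series: swapping the ring on the sulfonamide nitrogen

The source may hold more compounds than are shown below. What is called first, only, known or untested is meant among the compounds shown, and "the series" means these compounds.

Going by the values given here, in a functional assay on MCF7 cells (Homo sapiens) for antiproliferative activity, read by sulforhodamine B assay, with a stated time of 48 h (on this read-out lower numbers stand for stronger inhibition and higher numbers for weaker inhibition), compound 1 `CCc1ccc(NS(=O)(=O)c2ccc(N3CCNC3=O)cc2)cc1` gives 810 nM, the lower of the two numbers so far, though only by a margin inside the scatter. Compound 2 `CCCCOc1ccc(NS(=O)(=O)c2ccc(N3CCNC3=O)cc2)cc1` gives 870 nM; the step of a 1.1-fold higher number from compound 1 to compound 2 (0.03 log units; within the scatter) shows that changing the group on the aromatic carbon leaves the read-out unchanged. Compound 3 `COc1cccc(NS(=O)(=O)c2ccc(N3CCNC3=O)cc2)c1` is still unmeasured and differs from compound 1 by 3-methoxyphenyl in place of 4-ethylphenyl on a sulfonamide nitrogen. Among the compounds with values here, no measured step covers a replacement of the whole aryl group on the sulfonamide nitrogen, so no direct guide exists; the flat step seen so far suggests little movement. Compound 3 is therefore expected to show a 1.5-fold higher number from compound 1 to compound 3 (0.17 log units; within the scatter). The estimate for compound 3 is 1200 nM, with a range of 450 nM to 3200 nM.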

Compound 3, half-maximal inhibitory concentration: 120 nM
For compound 3 the middle estimate is 10-fold (1.00 log units) above the measured one; the whole stated range lies above it.
By their numbers in this assay, from the lowest: compound 3; then compounds 1 and 2 (each within the scatter of the next).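

Going by these compounds alone, the nitrogen substituent is the first place where a change moves the read-out. In this assay, 3-methoxyphenyl in place of 4-ethylphenyl gives a 6.8-fold lower number from compound 1 to compound 3 (0.83 log units; beyond the scatter), while a 1.1-fold higher number from compound 1 to compound 2 (0.03 log units; within the scatter) stayed flat. With one pair, the contribution of the oxygen cannot be separated from that of the group's placement on the ring, and nothing available explains the step. The compounds shown leave open how far this step extends to other groups. An amine or a carboxylic acid in place of the methoxy group of compound 3 remains an open case.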